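Dropping one hydroxy group: what compound 4 may give

The compounds below may be only part of what the source reports. "The series", "measured", "known", "first", "only" and "open" are said of these compounds alone.

Measured so far in a physicochemical assay, read by spectrophotometry, with a stated time of 30 min; on this read-out lower numbers stand for an effect already at smaller amounts and higher numbers for an effect only at larger amounts of compound:
Compound 1, `COc1cccc([C@@H]2Oc3cc(O)cc(O)c3C(=O)[C@H]2O)c1`: > 100000 nM, a limit of the assay.
Compound 2, `O=C1c2c(O)cc(O)cc2O[C@@H](c2cc(O)ccc2O)[C@@H]1O`: 25400 nM.
Compound 3, `O=C1c2c(O)cc(O)cc2O[C@H](c2cccc(O)c2)[C@H]1O`: > 100000 nM, a limit of the assay.

Among these, compound 2 is the only one that gives a number in this assay; the other two stop at the limit of > 100000 nM in this assay, at which 2 of the 3 values shown sit. Compound 4, `O=C1c2c(O)cc(O)cc2O[C@@H](c2ccccc2O)[C@@H]1O`, is not yet measured. Against compound 2 it differs by hydrogen in place of hydroxy on an aromatic carbon. For the measured compounds named here, no measured pair shows this change, so no size can be read off. Compound 3, which also carries a hydroxy on that ring, reaches only a limit. Compound 4 is therefore expected to come out weaker, the expected step being a 3.1-fold higher number from compound 2 to compound 4 (0.50 log units; beyond the scatter). The estimate for compound 4 is 80000 nM, within 25000 nM to 300000 nM, and quite possibly only a limit.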

Compound 4, half-maximal effective concentration: > 100000 nM
Compound 4: a limit, no number (the forecaster's own chance of this, stated with the estimate: 55%); middle value at least 1.2-fold (0.09 log units) away from the limit.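

Hydrogen in place of the hydroxy group that sits meta to a large group and para to a hydroxy group gives an at least 3.9-fold higher number from compound 2 to compound 4 (0.59 log units; beyond the scatter) in this assay. For the compounds shown here, this is the first single-change pair here, and it shows that the number given by compound 2 depends on this one hydroxy group. The step is only a lower bound, because compound 4 stops at a limit: the limit of > 100000 nM in this assay, at which 3 of the 4 values shown sit.

Going by these compounds, how much weaker compound 4 really is remains open. So does whether an amine or a carboxylic acid at this place could stand in for the hydroxy group.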